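The source may report more compounds than this note shows. Statements on the series, on what has been measured and on what is new or still open speak of the compounds shown alone.

Three compounds share one core and differ only in the group carried on an amide-type nitrogen: compound 1 `CNC(=O)C1=CC(C)(C)Oc2ccc([N+](=O)[O-])cc21`, compound 2 `CC(C)NC(=O)C1=CC(C)(C)Oc2ccc([N+](=O)[O-])cc21` and compound 3 `CC1(C)C=C(C(=O)NC2CC2)c2cc([N+](=O)[O-])ccc2O1`. In a functional assay on the whole organism (muscle tissue) with Rattus norvegicus as the target (on this read-out higher numbers stand for larger maximal responses and lower numbers for smaller maximal responses), compound 1 gives 61%, compound 2 gives 77.6% and compound 3 gives 78%. Compound 3 thus shows the highest of the three numbers, yet compound 2 sits within the usual scatter of it, so these two cannot be told apart, while compound 1 lies clearly lower. The unmeasured compound 4 `CC1(C)C=C(C(=O)NCC2CC2)c2cc([N+](=O)[O-])ccc2O1` carries cyclopropylmethyl in place of cyclopropyl on an amide-type nitrogen. For the measured compounds named here, two measured steps bear on such a change: a number 16.6 percentage points higher from compound 1 to compound 2 (beyond the scatter) and a number 17 percentage points higher from compound 1 to compound 3 (beyond the scatter), both modest gains when methyl gave way to a larger group. The step of a number 0.4 percentage points higher from compound 2 to compound 3 (within the scatter), where one larger group replaced another, stayed within the scatter. The change in compound 4 again swaps one larger group for another, and the expected step is therefore no change at the digits printed from compound 3 to compound 4 (within the scatter). For compound 4 in this assay the estimated value is 78%, between 66% and 90%.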

Compound 4, intrinsic activity: the largest response reached, in percent of the reference agonist's: 89.3%
The estimate for compound 4 lay 11.3 percentage points below the measured number; the measured number falls inside the stated range.
By their numbers in this assay, from the lowest: compound 1; then compounds 2 and 3 (each within the scatter of the next); then compound 4.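

Moving to cyclopropylmethyl on the amide-type nitrogen in this assay gives a number 11.3 percentage points higher from compound 3 to compound 4 (beyond the scatter) and a number 11.7 percentage points higher from compound 2 to compound 4 (beyond the scatter), so the larger groups are not interchangeable here, even though isopropyl and cyclopropyl could not be told apart. The three-membered ring is present in both compound 3 and compound 4, and the group only grows from 3 heavy atoms to 4, so a small change at this position can move the maximal response beyond the scatter; the full change from methyl is a number 28.3 percentage points higher from compound 1 to compound 4 (beyond the scatter). Nothing available here explains why this group behaves differently. The compounds shown leave open whether the rise continues with a longer chain such as n-butyl or a larger ring such as cyclobutylmethyl. They also leave open how a chain ending in an amine would fare at this position.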